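A few compounds are considered here, and "the series" means these few. Any claim that something is new, unique, unknown or untested is made for them only; others in the source may bear on it.

Measured in a functional assay on LoVo cells (Homo sapiens) for inhibition, read by colorimetric assay and MTT assay, with a stated time of 72 h; a lower number here means a stronger inhibitor, a higher number a weaker inhibitor:
- compound 1 `C=CCCCCOc1ccccc1-c1cnc(OCCCC=C)n1C`: 4000 nM
- compound 2 `C=CCCCCOc1ccccc1-c1cnc(OCCCCC=C)n1C`: 5000 nM
- compound 3 `C=CCCCCOc1ncc(-c2ccccc2OC)n1C`: 4000 nM

Compound 4 `C=CCCCCOc1ccccc1-c1cnc(OC)n1C` is still unmeasured. It differs from compound 2 by one change: hydrogen in place of pent-4-en-1-yl on a saturated chain carbon bound to an oxygen on an aromatic ring. In other words, hex-5-en-1-yl gives way to methyl, which leaves a methoxy group.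

Compound 2 stands within the scatter of the other two compounds, and both of its steps bear on this change. The first, a 1.3-fold higher number from compound 1 to compound 2 (0.10 log units; within the scatter), altered the same chain. The second, a 1.3-fold lower number from compound 2 to compound 3 (0.10 log units; within the scatter), made the same exchange elsewhere in the molecule. Neither step goes beyond the scatter, so no step beyond the scatter is expected in this assay.

The estimated step is no change at the digits printed from compound 2 to compound 4 (within the scatter). For the measured compounds named here, no measured compound has so short a chain at this place, so the range is kept wide. For compound 4 the expected value is 5000 nM, within an estimated range from 2500 nM to 15000 nM.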

Compound 4, half-maximal inhibitory concentration: 47000 nM
Beside the measured number, compound 4's estimate is 9.4-fold (0.97 log units) below it; measured number above the stated range.
By their numbers in this assay, from the lowest: compounds 1, 3 and 2 (each within the scatter of the next); then compound 4.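

Cutting the chain on this oxygen down to methyl matters in this assay, giving a 9.4-fold higher number from compound 2 to compound 4 (0.97 log units; beyond the scatter) and a 12-fold higher number from compound 1 to compound 4 (1.07 log units; beyond the scatter). The same exchange at the other oxygen gave only a 1.3-fold lower number from compound 2 to compound 3 (0.10 log units; within the scatter), so the two places do not respond alike. Nothing available explains this difference.

The compounds shown leave open how short the chain can become before the number rises, since an ethyl or propyl chain would fall in the gap. They also leave open whether an amine or a carboxylic acid at the chain end would serve as well as the alkene.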